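Cyclobutyl amide to methoxyazetidinyl urea: lipophilicity outlook

The compounds below may be only part of what the source reports. "The series", "measured", "known", "first", "only" and "open" are said of these compounds alone.

Measured so far in a physicochemical assay for lipophilicity, read by HPLC; on this read-out higher numbers stand for higher lipophilicity and lower numbers for lower lipophilicity:
- compound 1 `CCn1c(-c2ccc(C(F)(F)F)nc2)nc2c(O[C@H]3CCN(C(=O)N4CC(OC)C4)C3)ncnc21` gives 2.1
- compound 2 `CCn1c(-c2cnc(C)nc2)nc2c(O[C@H]3CCN(C(=O)C4CCC4)C3)ncnc21` gives 1.3
- compound 3 `CCn1c(-c2cnc(C)nc2)nc2c(N[C@H]3CCN(C(=O)[C@H]4C[C@@H](OC)C4)C3)ncnc21` gives 0.9

Compound 2 stands second highest of the three numbers in this assay. Its nearest neighbour is compound 3, whose value is lower by an amount beyond the scatter; the furthest is compound 1, whose value is higher, again beyond the scatter. No pair among these three differs in one place only, so no single-point step can be read from them; each pair differs in more than one region of the molecule.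

Compound 4 `CCn1c(-c2cnc(C)nc2)nc2c(O[C@H]3CCN(C(=O)N4CC(OC)C4)C3)ncnc21` is not yet measured. It differs from compound 2 in one place:

3-methoxyazetidin-1-yl in place of cyclobutyl on a carbonyl carbon

The enters group brings one hetero atom into the four-membered ring and one hydrogen-bond acceptor where the leaves group had none. Within the data shown here, nothing among the measured compounds isolates this change, so the expectation rests on the change alone. A downward step is expected from compound 2 to compound 4, of a size around a number 0.40 log units lower from compound 2 to compound 4 (beyond the scatter), modest but likely beyond the scatter. Compound 4 is accordingly estimated at 0.9, in the range 0.4 to 1.4.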

Compound 4, distribution coefficient: 0.9
Beside the measured number, compound 4's estimate shows no gap at the digits printed; the measured number falls inside the stated range.
By their numbers in this assay, from the lowest: compounds 3 and 4 (each within the scatter of the next); then compound 2; then compound 1.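

In this assay, among these compounds, 3-methoxyazetidin-1-yl in place of cyclobutyl on a carbonyl carbon now has a direct reading, a number 0.40 log units lower from compound 2 to compound 4 (beyond the scatter), a modest step that no earlier pair could isolate. With the (3-methoxyazetidin-1-yl)carbonyl group held constant, 2-methylpyrimidin-5-yl in place of 6-(trifluoromethyl)pyridin-3-yl on an aromatic carbon gives a number 1.20 log units lower from compound 1 to compound 4 (beyond the scatter), a large step that opens a second single-place reading in the series. The data shown give no measured basis for explaining either step.

Still open is whether the change on the carbonyl carbon keeps its size when 6-(trifluoromethyl)pyridin-3-yl replaces 2-methylpyrimidin-5-yl on the aromatic carbon, as only one such pair is shown, with 2-methylpyrimidin-5-yl present in both compounds. The compounds shown also leave open how a hydroxyl group or a longer ethoxy chain in place of the methoxy group on the four-membered ring would read in this assay, and whether a morpholine in place of 3-methoxyazetidin-1-yl on the carbonyl carbon would follow the same direction.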